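Replacing the aryl amide on the shared core by a propanoyl group

The source may hold more compounds than are shown below. What is called first, only, known or untested is meant among the compounds shown, and "the series" means these compounds.

Compound 1, `O=C(c1ccc(Cl)cc1)N1CCN(c2nc(=O)c3cc(C(F)(F)F)cc([N+](=O)[O-])c3s2)CC1`: 5.19 ug/mL
Compound 2, `Cc1ccc(C(=O)N2CCN(c3nc(=O)c4cc(C(F)(F)F)cc([N+](=O)[O-])c4s3)CC2)cc1`: 6.7 ug/mL
Compound 3, `O=C(c1cccc(F)c1)N1CCN(c2nc(=O)c3cc(C(F)(F)F)cc([N+](=O)[O-])c3s2)CC1`: 0.2 ug/mL

The three measured compounds share one core and differ only in the group on the carbonyl carbon that sits on the amide-type nitrogen in a ring. In a physicochemical assay for solubility, read by HPLC (on this read-out lower numbers stand for lower solubility and higher numbers for higher solubility), compound 1 gives 5.19 ug/mL and compound 2 gives 6.7 ug/mL; the step between them, a 1.3-fold higher number from compound 1 to compound 2 (0.11 log units; within the scatter), stays within the scatter. Compound 3 stands lowest of the three, far from both: a 26-fold lower number from compound 1 to compound 3 (1.41 log units; beyond the scatter) and a 34-fold lower number from compound 2 to compound 3 (1.53 log units; beyond the scatter).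

Compound 4, `CCC(=O)N1CCN(c2nc(=O)c3cc(C(F)(F)F)cc([N+](=O)[O-])c3s2)CC1`, takes the next step at the same place: ethyl in place of 3-fluorophenyl on a carbonyl carbon. The two measured changes at this carbonyl carbon, a 26-fold lower number from compound 1 to compound 3 (1.41 log units; beyond the scatter) and a 34-fold lower number from compound 2 to compound 3 (1.53 log units; beyond the scatter), were both large, so a further change there is expected to move this assay by a large step, and the direction expected is upward. The step expected is a 30-fold higher number from compound 3 to compound 4 (1.48 log units; beyond the scatter). Compound 4 is therefore estimated at 6 ug/mL, within a range from 1 ug/mL to 35 ug/mL.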

Compound 4, solubility: 3.29 ug/mL
Compound 4: middle estimate off by 1.8-fold (0.26 log units), on the high side; measured number inside the range.
By their numbers in this assay, from the lowest: compound 3; then compounds 4, 1 and 2 (each within the scatter of the next, the first and the last beyond it).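

Without any aromatic ring on the carbonyl carbon, the number in this assay is still far above that of the 3-fluorophenyl amide, with a 16-fold higher number from compound 3 to compound 4 (1.22 log units; beyond the scatter) as the step, so an aryl group at this place is not required for the higher numbers. Among the compounds shown here, the small ethyl also lands close to the other two aryl groups, with a 1.6-fold lower number from compound 1 to compound 4 (0.20 log units; within the scatter) staying within the scatter and a 2.0-fold lower number from compound 2 to compound 4 (0.31 log units; beyond the scatter) lying just beyond it as a modest step, which leaves compound 3 as the one low number of the four. Nothing available here explains why compound 3 stands apart.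

Still open, as far as these compounds go, is whether that low number belongs to the fluorine or to the 3-fluorophenyl group as a whole. Also open, from the compounds shown here alone, is how a longer chain, or a chain carrying an amine or a carboxylic acid, would read on this carbonyl carbon.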